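The source may report more compounds than this note shows. Statements on the series, on what has been measured and on what is new or still open speak of the compounds shown alone.

Compound 1 `Nc1scc(CN2CCN(c3ccccc3C(F)(F)F)CC2)c1C(=O)c1ccc(Cl)cc1` gives 0% in an assay on CHO cells for displacement of a labelled ligand from adenosine receptor A3 (Homo sapiens), read by scintillation counting, with a stated time of 120 min, tested at 10 uM; a higher number here means more inhibition at the concentration tested (going by the name of the read-out), a lower number less inhibition. Compound 2 `Nc1scc(CN2CCN(c3ccc(C(F)(F)F)cc3)CC2)c1C(=O)c1cccc(C(F)(F)F)c1` gives 0% in this assay, so compound 1 stands level with compound 2 at the digits shown, the two values within the usual scatter; no step between measured compounds is available, and both values sit at the bottom of the read-out. Compound 3 `Nc1scc(CN2CCN(c3cc(F)cc(F)c3)CC2)c1C(=O)c1ccc(Cl)cc1` differs from compound 1 in one place: 3,5-difluorophenyl in place of 2-(trifluoromethyl)phenyl on an amine nitrogen in a ring. Given the two measured values, the step of a number 5 percentage points higher from compound 1 to compound 3 (within the scatter) is expected to be none beyond the scatter. Compound 3 is estimated at 5%, with a range from 0% to 25%.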

Compound 3, a percentage reported as inhibition, at one concentration (the size of the read-out at that concentration, not a potency): 2%
Beside the measured number, compound 3's estimate is 3 percentage points above it; the measured number falls inside the stated range.
By their numbers in this assay, from the lowest: compounds 1, 2 and 3 (each within the scatter of the next).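

In this assay, 3,5-difluorophenyl in place of 2-(trifluoromethyl)phenyl on the amine nitrogen in a ring gives a number 2 percentage points higher from compound 1 to compound 3 (within the scatter). Within the data shown here, this is the first single-place comparison, and at this position the two fluorinated phenyl groups cannot be told apart, with both compounds at the bottom of the read-out. No measurement is available to account for this result.

On these data alone, whether any group at this position can raise the read-out remains open, for example a carboxylic acid or an amine on the phenyl ring. With all values at the bottom of the read-out, the importance of this position cannot yet be judged.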